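Bromo for chloro in two matched pairs of the series

The source may hold more compounds than are shown below. What is called first, only, known or untested is meant among the compounds shown, and "the series" means these compounds.

All numbers here come from an ADME assay on MCF-10A cells (Homo sapiens) for cytotoxicity, read by sulforhodamine B assay, with a stated time of 48 h; a higher number here means a weaker inhibitor of growth, a lower number a stronger inhibitor of growth.

Measured so far:
compound 1 `O=C1C(=O)N(CN2CCN(c3ccnc4cc(Cl)ccc34)CC2)c2cc(Cl)ccc21`: 67800 nM
compound 2 `O=C1C(=O)N(CN2CCN(c3ccnc4cc(Cl)ccc34)CC2)c2cc(Br)ccc21`: 18000 nM
compound 3 `NC(=S)N/N=C1/C(=O)N(CN2CCN(c3ccnc4cc(C(F)(F)F)ccc34)CC2)c2cccc(Cl)c21`: 51700 nM

Compound 1 and compound 2 share a core and differ in one place, (bromo in place of chloro on an aromatic carbon); the step is a 3.8-fold lower number from compound 1 to compound 2 (0.58 log units; beyond the scatter). Compound 3 carries a different core, and the difference between the two cores is not broken down here. Its number in this assay lies close to that of compound 1, within the usual scatter, so no order between compound 1 and compound 3 is claimed; the number of compound 2 is lower than that of compound 3 by a gap beyond the scatter.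

Compound 4 `NC(=S)N/N=C1/C(=O)N(CN2CCN(c3ccnc4cc(C(F)(F)F)ccc34)CC2)c2cccc(Br)c21` is not yet measured. It stands to compound 3 as compound 2 stands to compound 1: bromo in place of chloro on an aromatic carbon. The change is the same kind of change, not the same, since the surroundings differ: in compound 1 to compound 2 the carbon is meta to a fused ring and para to a fused ring, while in compound 3 to compound 4 it is ortho to a fused ring and meta to a fused ring.

Within the data shown here, for compound 4 in this assay a step of a 2.4-fold lower number from compound 3 to compound 4 (0.37 log units; beyond the scatter) is expected, somewhat smaller than the measured step because a 3.8-fold lower number from compound 1 to compound 2 (0.58 log units; beyond the scatter) is the only pair that supports the direction, and the place of the change differs. The estimate for compound 4 is 22000 nM, with a plausible range from 9000 nM to 55000 nM.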

Compound 4, concentration for 50% growth inhibition: 30600 nM
Beside the measured number, compound 4's estimate is 1.4-fold (0.14 log units) below it, within the range that was stated.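

In this assay, bromo in place of chloro on the core of compound 3 gives a 1.7-fold lower number from compound 3 to compound 4 (0.23 log units; within the scatter), so no order between the two compounds is claimed. Set beside the earlier pair, the second step cannot be separated from the first, and the comparison reads: the same change on two cores in this assay, a 3.8-fold lower number (0.58 log units; beyond the scatter) from compound 1 to compound 2 and a 1.7-fold lower number (0.23 log units; within the scatter) from compound 3 to compound 4, 2.2-fold (0.35 log units) apart, within the scatter of two such steps. This shows that the two steps are compatible with one shared effect of the change and gives no ground for calling the change core-dependent, but it does not show that the effect carries over, since only the first step lies beyond the scatter, and with just two pairs, which differ both in core and in the place of the halogen, the influence of core and place cannot be told apart.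

Still open, going by these compounds, is whether the step seen on the core of compound 1 would hold at the place the halogen occupies in compound 3, and the reverse, which would separate the core from the place. Also open, on these data alone, is how fluoro, iodo, methyl or a nitrile on the same aromatic carbon would compare with chloro and bromo on either core.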